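Cytotoxicity notes: aryl amide series, methylsulfonyl analogue pending

The compounds below may be only part of what the source reports. "The series", "measured", "known", "first", "only" and "open" are said of these compounds alone.

Measured so far:
Compound 1, `COc1ccc(F)c(-c2ccc(C(=O)N(Cc3cccc(OCCCCCC(=O)O)c3)C(C)C)cc2)c1`. In an ADME assay on HepG2 cells (Homo sapiens) for cytotoxicity, read by CellTiter-Glo and resazurin assay, with a stated time of 72 h (on this read-out lower numbers stand for an effect already at smaller amounts and higher numbers for an effect only at larger amounts of compound), compound 1 sits at a limit, > 26000 nM.
Compound 2, `CC(C)N(Cc1cccc(OCCCCCC(=O)O)c1)C(=O)c1ccc(-c2cccc(Cl)c2)cc1`. In this assay compound 2 sits at a limit, > 21900 nM.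

Both measured compounds give only limits the limit of > 21900 nM in this assay, at which 1 of the 2 values shown sits (the limit of > 26000 nM in this assay, at which 1 of the 2 values shown sits), so a step that the two limits leave unreadable from compound 1 to compound 2 cannot be read. Compound 3, `CC(C)N(Cc1cccc(OCCCCCC(=O)O)c1)C(=O)c1ccc(-c2cccc(S(C)(=O)=O)c2)cc1`, carries methylsulfonyl in place of chloro on an aromatic carbon. Among the compounds with values here, no measured step bears on this change, and compound 2 itself stands at a limit. For compound 3 in this assay a value of 30000 nM is expected, range 10000 nM to 100000 nM, most likely again reported only as a limit. The expected step is a step that the limit leaves unreadable from compound 2 to compound 3, no more than scatter.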

Compound 3, half-maximal effective concentration: > 26000 nM
Compound 3 was reported as a limit (the forecaster's own chance of this, stated with the estimate: 80%); the middle value does not contradict the limit.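

In this assay, within the data shown here, compound 3 gives > 26000 nM, a limit, as compound 1 and compound 2 also stand only at limits, so no step among the three can be read. Going by these compounds, whether methylsulfonyl and chloro differ at all in this assay stays open.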